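A few compounds are considered here, and "the series" means these few. Any claim that something is new, unique, unknown or untested is made for them only; others in the source may bear on it.

For the measured compounds named here, in a functional assay on PC-3 cells (Homo sapiens) for cytotoxicity, read by MTT assay, with a stated time of 48 h (a lower number here means a stronger inhibitor, a higher number a weaker inhibitor), compound 1 `CC1(C)CCC[C@]2(C)[C@@H](CC[C@@](C)(O)/C=C/c3cncc4ccccc34)[C@](C)(O)CC[C@@H]12` gives 3900 nM and compound 2 `CC(C)(C)c1ccc(/C=C/[C@](C)(O)CC[C@@H]2[C@@]3(C)CCCC(C)(C)[C@@H]3CC[C@@]2(C)O)cc1` gives 3800 nM, so compound 2 stands level with the only other measured compound. Compound 3 `COc1cccc(/C=C/[C@](C)(O)CC[C@@H]2[C@@]3(C)CCCC(C)(C)[C@@H]3CC[C@@]2(C)O)c1OC` differs from compound 2 by 2,3-dimethoxyphenyl in place of 4-(tert-butyl)phenyl on a double-bonded chain carbon bound to a double-bonded chain carbon, with 2,3-dimethoxyphenyl in place of 4-(tert-butyl)phenyl on a double-bonded chain carbon. Going by the values given here, the one measured step, a 1.0-fold lower number from compound 1 to compound 2 (0.01 log units; within the scatter), exchanged a group at that same place and stayed within the scatter. On that single precedent, the expected step in this assay is a 1.1-fold higher number from compound 2 to compound 3 (0.02 log units; within the scatter), none beyond the scatter. For compound 3 the estimated value is 4000 nM, with an expected range of 1800 nM to 8500 nM.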

Compound 3, half-maximal inhibitory concentration: 2900 nM
Compound 3: middle estimate off by 1.4-fold (0.14 log units), on the high side; measured number inside the range.
By their numbers in this assay, from the lowest: compounds 3, 2 and 1 (each within the scatter of the next).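

Placing 2,3-dimethoxyphenyl on a double-bonded chain carbon bound to a double-bonded chain carbon gives, in this assay, a 1.3-fold lower number from compound 2 to compound 3 (0.12 log units; within the scatter) and a 1.3-fold lower number from compound 1 to compound 3 (0.13 log units; within the scatter), both within the scatter. Thus 2,3-dimethoxyphenyl, with hydrogen-bond acceptors where 4-(tert-butyl)phenyl has none, leaves the number level, and the three groups shown at this place cannot be told apart. Nothing available explains this result. As far as these compounds go, whether an amine or a carboxylic acid on the ring at this place would move the number beyond the scatter stays open.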